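Swapping an ethylphenyl for a methylfuranyl on a hydroxamic acid

This account rests on a few compounds, and the source may have more. Where it says the series, first, only, none or still open, it means among the compounds named here.

Within the data shown here, compound 2 `CCc1ccc(-c2nc(CNc3ccc(C(=O)NO)cc3)n(-c3ccccc3)n2)cc1` is one of two compounds measured in an assay on Sf9 cells for inhibition of protein deacetylase HDAC6 (Homo sapiens), read by fluorescence, with a stated time of 40 min, tested at 100 nM (a lower number here means less inhibition, a higher number more inhibition at the concentration tested (going by the name of the read-out)), where compound 2 gives 54.6%. Compound 1 `COc1ccc(-c2nc(CNc3ccc(C(=O)NO)cc3)n(-c3ccccc3)n2)cc1` gives 77.6% in this assay, so compound 2 holds the lower of the two numbers. Among the measured compounds shown here, the only measured step, a number 23 percentage points lower from compound 1 to compound 2 (beyond the scatter), concerns a change at the same place in the shared core as the change now considered. Compound 3 `Cc1ccc(-c2nc(CNc3ccc(C(=O)NO)cc3)n(-c3ccccc3)n2)o1` differs from compound 2 by a single change: 5-methylfuran-2-yl in place of 4-ethylphenyl on an aromatic carbon. Because the measured step of a number 23 percentage points lower from compound 1 to compound 2 (beyond the scatter) swapped one small group for another rather than one ring for another, it guides this case only weakly, showing merely that changes at this place can move the read-out beyond the scatter. The expected step is therefore a number 3.4 percentage points higher from compound 2 to compound 3 (within the scatter), small and uncertain. The estimate for compound 3 is 58%, with a range from 30% to 80%.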

Compound 3, a percentage reported as inhibition, at one concentration (the size of the read-out at that concentration, not a potency): 60.7%
Compound 3: the middle estimate sits 2.7 percentage points below what was measured; the measured number falls inside the stated range.
By their numbers in this assay, from the lowest: compounds 2 and 3 (each within the scatter of the next); then compound 1.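

In this assay, 5-methylfuran-2-yl in place of 4-ethylphenyl gives a number 6.1 percentage points higher from compound 2 to compound 3 (within the scatter), so at this position a five-membered aromatic ring with 1 hetero atom stands level with a six-membered aromatic ring of carbon only, within the scatter. The comparison with the third compound adds that 5-methylfuran-2-yl in place of 4-methoxyphenyl gives a number 16.9 percentage points lower from compound 1 to compound 3 (beyond the scatter), which leaves compound 1 with the highest number of the three, its steps to both others being beyond the scatter. No measurement at hand gives a reason for these numbers.

As far as these compounds go, it stays open what a furan-2-yl group without its methyl would give at this position. From the compounds shown here alone, it also stays open whether a phenyl ring carrying an amine or a carboxylic acid would match 4-methoxyphenyl.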